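Acetamido for methoxy on a biaryl imidazole carbinol

A few compounds are considered here, and "the series" means these few. Any claim that something is new, unique, unknown or untested is made for them only; others in the source may bear on it.

Compound 1 `COc1ccc(-c2ccc(C(O)(c3c[nH]cn3)C(C)C)cc2)cc1`: 54 nM
Compound 2 `CC(=O)Nc1cccc(-c2ccc([C@@](O)(c3c[nH]cn3)C(C)C)cc2)c1`: 340 nM

Compound 1 holds the lowest number of the two measured compounds in an assay on isolated protein for inhibition of steroid 17-alpha-hydroxylase/17,20 lyase (Homo sapiens); on this read-out lower numbers stand for stronger inhibition and higher numbers for weaker inhibition; compound 2 stands at a higher number, a gap beyond the usual scatter. Compound 3 `CC(=O)Nc1ccc(-c2ccc(C(O)(c3c[nH]cn3)C(C)C)cc2)cc1` carries an acetamido in place of methoxy on an aromatic carbon, para to a large group (acetamido in place of methoxy on an aromatic carbon). For the measured compounds named here, no measured pair isolates this change, so its size is open. Compound 3 is expected to give 100 nM (range 30 nM to 350 nM), a modest weakening from compound 1 that may fall within the scatter, as stated by a 1.9-fold higher number from compound 1 to compound 3 (0.27 log units; within the scatter).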

Compound 3, half-maximal inhibitory concentration: 120 nM
Beside the measured number, compound 3's estimate is 1.2-fold (0.08 log units) below it; measured number inside the range.
By their numbers in this assay, from the lowest: compound 1; then compound 3; then compound 2.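

In this assay, acetamido in place of methoxy on an aromatic carbon, para to a large group, gives a 2.2-fold higher number from compound 1 to compound 3 (0.35 log units; beyond the scatter) and so puts a first measured size on this change. The weakening is modest, so this place accepts the larger acetamido, with its hydrogen-bond donor, without a severe loss. Nothing in hand accounts for the step.

Going by these compounds, whether an amine, a carboxylic acid or a longer chain at this place would stay closer to compound 1 remains open. Also open, on these data alone, is whether the methoxy or the acetamido itself drives the difference, which a plain hydrogen at this place would help to settle.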